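Methoxy for Methyl on a Thiourea Series

The source may report more compounds than this note shows. Statements on the series, on what has been measured and on what is new or still open speak of the compounds shown alone.

Compound 1, `Cc1ccc(NC(=S)NC(=O)c2cn(-c3ccccc3)nc2-c2ccc(F)cc2)cc1`, gives 2080 nM in a functional assay on A549 cells (Homo sapiens) for inhibition, read by CCK-8 assay, with a stated time of 48 h; a higher number here means a weaker inhibitor, a lower number a stronger inhibitor.
Compound 2, `Cc1ccc(-c2nn(-c3ccccc3)cc2C(=O)NC(=S)Nc2ccc(Cl)cc2)cc1`, gives 3170 nM.
Compound 3, `Cc1ccc(NC(=S)NC(=O)c2cn(-c3ccccc3)nc2-c2ccc(C)cc2)cc1`, gives 2830 nM.

Compound 2 carries the highest of the three numbers, yet all three sit within the scatter of one another, so no ranking can be drawn. Compound 4, `COc1ccc(-c2nn(-c3ccccc3)cc2C(=O)NC(=S)Nc2ccc(Cl)cc2)cc1`, differs from compound 2 by methoxy in place of methyl on an aromatic carbon. Among the measured compounds shown here, two measured steps bear on this: a 1.4-fold higher number from compound 1 to compound 3 (0.13 log units; within the scatter) and a 1.1-fold lower number from compound 2 to compound 3 (0.05 log units; within the scatter). Both exchanged one small group for another on an aromatic carbon and moved nothing beyond the scatter. The swap of methyl for methoxy in the shared core is expected to behave alike, so the step of a 1.1-fold lower number from compound 2 to compound 4 (0.02 log units; within the scatter) is estimated to stay within the scatter. Compound 4 is therefore expected to give about 3000 nM in this assay, between 1500 nM and 6500 nM.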

Compound 4, half-maximal inhibitory concentration: 1310 nM
The estimate for compound 4 lay 2.3-fold (0.36 log units) above the measured number; the measured number lies below the stated range.
By their numbers in this assay, from the lowest: compounds 4, 1, 3 and 2 (each within the scatter of the next, the first and the last beyond it).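

Going from 4-methylphenyl to 4-methoxyphenyl gives a 2.4-fold lower number from compound 2 to compound 4 (0.38 log units; beyond the scatter) in this assay, a modest change, but the first step shown here to pass beyond the scatter. The earlier swaps of small groups on aromatic carbons did not, so this position does respond to at least one such exchange. No measurement here explains the difference.

On these data alone, it remains open whether a hydroxyl or ethoxy group at this place would give a lower or higher number. Also open, as far as these compounds go, is whether methoxy would give a similar step with fluoro or methyl in place of the chloro of compound 4.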